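A few compounds are considered here, and "the series" means these few. Any claim that something is new, unique, unknown or untested is made for them only; others in the source may bear on it.

Of the compounds shown here, three have been measured in an assay for binding affinity to Alpha-1B adrenergic receptor (Homo sapiens); a lower number here means a stronger inhibitor, a higher number a weaker inhibitor. Compound 1 `CN1CCC(Cn2nc(Cc3ccc(Cl)cc3)c3ccccc3c2=O)C1` gives 79.4 nM, and compound 2 `O=c1c2ccccc2c(Cc2ccc(Cl)cc2)nn1C[C@H]1CCCN1CCCCCc1ccc(OCCCN2CCCCCC2)cc1` gives 50.1 nM. Compound 3 `CCCCCc1nn(C[C@H]2CCCN2C)c(=O)c2ccccc12` gives 1000 nM, the highest of the three numbers; its gaps to compound 1 and to compound 2 both lie beyond the scatter. Compound 4 `COc1ccc(Cc2nn(C[C@H]3CCCN3C)c(=O)c3ccccc23)cc1` has not yet been measured and differs from compound 3 in one place: 4-methoxyphenyl in place of butyl on a saturated chain carbon bound to an aromatic carbon. Within the data shown here, no measured pair isolates this same change, so the expectation rests on the nearest comparison in structure, compound 1, which gives 79.4 nM. The step from compound 3 to compound 4 is expected to be large and downward, a 13-fold lower number from compound 3 to compound 4 (1.10 log units; beyond the scatter). Compound 4 is therefore estimated at 80 nM, within a range of 25 nM to 300 nM.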

Compound 4, inhibition constant: 158 nM
The estimate for compound 4 lay 2.0-fold (0.30 log units) below the measured number, within the range that was stated.
By their numbers in this assay, from the lowest: compounds 2, 1 and 4 (each within the scatter of the next, the first and the last beyond it); then compound 3.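

In this assay, 4-methoxyphenyl in place of butyl on a saturated chain carbon bound to an aromatic carbon gives a 6.3-fold lower number from compound 3 to compound 4 (0.80 log units; beyond the scatter) and is the first change in one place among these compounds. It shows that the number responds to the group at this position, with the ring-bearing group giving the lower value in this single pair. Nothing available explains the size of this step.

As far as these compounds go, how an unsubstituted phenyl or a pyridine ring would read at this position remains open. So does the contribution of the methoxy group itself.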